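The source may report more compounds than this note shows. Statements on the series, on what has been measured and on what is new or still open speak of the compounds shown alone.

In a functional assay for inhibition, with Homo sapiens as the target (a higher number here means a weaker inhibitor, a lower number a stronger inhibitor), compound 2 `CC(C)c1ccc2oc(NC(CC3CCCCC3)c3ccccc3)nc2c1` gives 6 nM, the only number shown for it, and one further entry carries no single number. The closely related compound 1 `c1ccc(C(CC2CCCCC2)Nc2nc3ccccc3o2)cc1` gives 340 nM; 8 nM; 6 nM (3 entries). Compound 3 `CCOC(=O)c1ccc2oc(NC(CC3CCCCC3)c3ccccc3)nc2c1` has ethoxycarbonyl in place of isopropyl on an aromatic carbon. Going by the values given here, no measured step shows what this swap does, so a modest weakening in this assay is expected, meaning a higher number. The expected change is a 4.2-fold higher number from compound 2 to compound 3 (0.62 log units; beyond the scatter). The range stays wide because of the several entries of compound 1 in this assay, 340 nM; 8 nM; 6 nM (3 entries). For compound 3 the estimate is 25 nM, with an expected range from 5 nM to 150 nM.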

Compound 3, half-maximal inhibitory concentration: 45 nM
Compound 3: middle estimate off by 1.8-fold (0.26 log units), on the low side; the range from low to high includes it.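

In this assay, this aromatic carbon is sensitive to what it carries: a 7.5-fold higher number from compound 2 to compound 3 (0.88 log units; beyond the scatter). Ethoxycarbonyl, with its 2 hydrogen-bond acceptors, weakens inhibition compared with isopropyl, which has none, yet compound 3 still gives 45 nM, so the position tolerates this larger group to a degree. Nothing measured here explains why the number rises. As far as these compounds go, whether the rise goes with the acceptors or with the larger group stays open, and a carboxylic acid, an amine or a methyl ester on the same carbon could help separate the two.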